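The compounds below may be only part of what the source reports. "The series", "measured", "known", "first", "only" and "open" are said of these compounds alone.

Measured compounds:
Compound 1 `Cc1ccnc(OCc2ccc(F)cc2)c1C(=O)NC1CCCCCC1` gives > 10000 nM in an ADME assay on cells for inhibition of Fatty-acid amide hydrolase 1 (Homo sapiens), with stated times of 30 min and 15 min; a lower number here means a stronger inhibitor, a higher number a weaker inhibitor.
Compound 2 `COc1ccc(-c2cn(Cc3ccc(F)cc3)c(=O)c(C(=O)NC3CCCCCC3)c2C)cc1` gives 1300 nM in this assay.
Compound 3 `O=C(NC1CCCCCC1)c1c(-c2ccccc2)c(Br)cn(Cc2ccc(F)cc2)c1=O` gives > 10000 nM in this assay.

The value for compound 3 is a limit of this assay, not a number. Compound 3 thus stands at the limit of > 10000 nM in this assay, at which 2 of the 3 values shown sit, and no actual number is known for it. Compound 2 is the only one of the three with a measured number. Compound 4 `COc1ccc(-c2cn(Cc3ccc(F)cc3)c(=O)c(C(=O)NC3CCCCCC3)c2-c2ccccc2)cc1` differs from compound 3 by 4-methoxyphenyl in place of bromo on an aromatic carbon. Compound 2 also carries a 4-methoxyphenyl and gives 1300 nM, so compound 4 is expected to give a measurable number, with a step of an at least 4.0-fold lower number from compound 3 to compound 4 (0.60 log units; beyond the scatter) toward stronger inhibition. Compound 4 is estimated at 2500 nM, between 600 nM and 10000 nM.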

Compound 4, half-maximal inhibitory concentration: > 10000 nM
Compound 4 ended at the assay's limit; the forecaster's own chance of this, stated with the estimate: 35%; at least 4.0-fold (0.60 log units) between middle value and limit.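

The 4-methoxyphenyl group does not by itself secure a measurable number: with phenyl in place of methyl on an aromatic carbon, this assay shows an at least 7.6-fold higher number from compound 2 to compound 4 (0.88 log units; beyond the scatter). Compound 3 and compound 4 both stand at limits, so the step between them cannot be read. Compound 4 thus joins the compounds at the limit: the limit of > 10000 nM in this assay, at which 3 of the 4 values shown sit.

Still open, as far as these compounds go, is whether ethyl or an amine in place of that phenyl would keep a measurable number. From the compounds shown here alone, the true strength of the compounds at the limit also remains unknown.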